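Cyclopropyl to Ethyl on the Amide Nitrogen

The compounds below may be only part of what the source reports. "The series", "measured", "known", "first", "only" and "open" are said of these compounds alone.

Compound 3 `O=C(/C=C1\CCc2c(F)cc(F)cc21)NC1CC1` gives 100% in a functional assay on the whole organism with Mus musculus as the target, at a dose of 100 mg/kg by the intraperitoneal route; on this read-out lower numbers stand for less inhibition and higher numbers for more inhibition at the one dose given (going by the name of the read-out). Compound 1 `CN(C)C(=O)/C=C1\CCc2c(F)cc(F)cc21` gives 100% and compound 2 `CNC(=O)/C=C1\CCc2c(F)cc(F)cc21` gives 100%, so compound 3 stands level with both on this read-out. The move to compound 4 `CCNC(=O)/C=C1\CCc2c(F)cc(F)cc21` is ethyl in place of cyclopropyl on an amide-type nitrogen. For the measured compounds named here, three measured steps bear on it, each a change at the same amide-type nitrogen: no change at the digits printed from compound 1 to compound 2 (within the scatter), no change at the digits printed from compound 1 to compound 3 (within the scatter) and no change at the digits printed from compound 2 to compound 3 (within the scatter). None shifted the read-out beyond the scatter, and each substituent tried there gave the same level. A further exchange at this place is therefore expected to give no step beyond the scatter: no change at the digits printed from compound 3 to compound 4 (within the scatter). Compound 4 is estimated at 100%, with a range from 85% to 100%.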

Compound 4, a percentage reported as inhibition, in the whole organism at one dose (the size of the read-out at that dose, not a potency): 67%
Beside the measured number, compound 4's estimate is 33 percentage points above it, outside the stated range (below it).
By their numbers in this assay, from the lowest: compound 4; then compounds 1, 2 and 3 (each within the scatter of the next).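

The amide nitrogen is less forgiving than the first three compounds suggested: in this assay ethyl in place of cyclopropyl gives a number 33 percentage points lower from compound 3 to compound 4 (beyond the scatter) and not a level result. Methyl in place of hydrogen on the chain carbon gives a number 33 percentage points lower from compound 2 to compound 4 (beyond the scatter) and ethylamino in place of dimethylamino gives a number 33 percentage points lower from compound 1 to compound 4 (beyond the scatter), so ethyl alone among these substituents stands apart. Nothing available explains why this small change matters here.

From the compounds shown here alone, whether a longer chain such as propyl would read like ethyl or like cyclopropyl stays open. So does the effect of a hydroxyl group at the end of the ethyl chain.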